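Replacing the aryl group on the hydrazone carbon of compound 2

This account rests on a few compounds, and the source may have more. Where it says the series, first, only, none or still open, it means among the compounds named here.

Of the compounds shown here, three sharing one core have been measured in a functional assay on NCI-H460 cells (Homo sapiens) for cytotoxicity, read by MTT assay, with a stated time of 72 h; a higher number here means a weaker inhibitor, a lower number a stronger inhibitor. Compound 1 `COc1ccc(OC)c(/C=N/NC(=O)Nc2ccc(Oc3ccnc(-c4nncn4CCN(C)C)c3)c(F)c2)c1` gives 2930 nM. Compound 2 `COc1ccc(/C=N/NC(=O)Nc2ccc(Oc3ccnc(-c4nncn4CCN(C)C)c3)c(F)c2)c(OC)c1` gives 1570 nM, the lowest of the three numbers, though its gap to compound 3 `CN(C)CCn1cnnc1-c1cc(Oc2ccc(NC(=O)N/N=C/c3ccc(F)cc3F)cc2F)ccn1`, which gives 1930 nM, and its gap to compound 1 both stay within the scatter. The measured steps all sit at the same place, the carbon with a double bond to nitrogen: a 1.9-fold lower number from compound 1 to compound 2 (0.27 log units; within the scatter), a 1.5-fold lower number from compound 1 to compound 3 (0.18 log units; within the scatter) and a 1.2-fold higher number from compound 2 to compound 3 (0.09 log units; within the scatter), none beyond the scatter.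

Compound 4 `Cc1cc(/C=N/NC(=O)Nc2ccc(Oc3ccnc(-c4nncn4CCN(C)C)c3)c(F)c2)cc(C)c1O` is the next change at that same carbon: 4-hydroxy-3,5-dimethylphenyl in place of 2,4-dimethoxyphenyl on a carbon with a double bond to nitrogen. Among the compounds with values here, the entering group carries a hydrogen-bond donor, which none of the measured aryl groups had, so no step directly shows its effect. Since every exchange of the aryl group so far moved the number only within the scatter, compound 4 is expected to show a 1.1-fold higher number from compound 2 to compound 4 (0.06 log units; within the scatter), no step beyond the scatter. Compound 4 is estimated at 1800 nM, with a range from 800 nM to 4000 nM.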

Compound 4, half-maximal inhibitory concentration: 2010 nM
Compound 4: middle estimate off by 1.1-fold (0.05 log units), on the low side, and the stated range covers the measured number.
By their numbers in this assay, from the lowest: compounds 2, 3, 4 and 1 (each within the scatter of the next).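

In this assay, within the data shown here, the 4-hydroxy-3,5-dimethylphenyl group, the first aryl group here to carry a hydrogen-bond donor, gives a 1.3-fold higher number from compound 2 to compound 4 (0.11 log units; within the scatter) and a 1.0-fold higher number from compound 3 to compound 4 (0.02 log units; within the scatter) and a 1.5-fold lower number from compound 1 to compound 4 (0.16 log units; within the scatter). The position on the carbon with a double bond to nitrogen therefore accepts this donor-bearing ring as well as the methoxy and fluoro rings, and all four compounds remain within the scatter of one another. Nothing available explains why this exchange leaves the number so little changed.

The hydroxy and methyl groups enter together, so a plain 4-hydroxyphenyl group would be needed to separate their contributions. On these data alone, all four groups are substituted phenyl rings, so it remains open whether a pyridine ring, a carboxylic acid or a dimethylamino group at this position would move the number beyond the scatter.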